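The source may hold more compounds than are shown below. What is called first, only, known or untested is meant among the compounds shown, and "the series" means these compounds.

Measured in an ADME assay on the whole organism (Mus musculus, strain CD-1) for pharmacokinetics, at a dose of 10 mg/kg by the oral route; on this read-out higher numbers stand for higher exposure at the dose given and lower numbers for lower exposure:
- compound 1 `CCCOc1cc([C@](O)(CCN(C)C)[C@@H](c2cc3cc(Br)ccc3nc2OC)c2ccnc(OC)c2OC)cc(OC)n1`: 10900 ng.h/mL
- compound 2 `COc1cc([C@](O)(CCN(C)C)[C@@H](c2cc3cc(Br)ccc3nc2OC)c2ccnc(OC)c2OC)cc(OC2CCC2)n1`: 8400 ng.h/mL
- compound 3 `COc1cc([C@](O)(CCN(C)C)[C@@H](c2cc3cc(C#N)ccc3nc2OC)c2cccc(OC)c2F)cc(SC)n1`: 1100 ng.h/mL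

Compound 1 stands at the top of these three numbers together with compound 2, the two lying within the scatter of each other. Compound 3, at 1100 ng.h/mL, lies well beyond the scatter from compound 1.

Next in the series is compound 4 `COc1nc2ccc(Br)cc2cc1[C@@H](c1ccnc(OC)c1OC)[C@@](O)(CCN(C)C)c1cc(SC)nc(SC)c1`, which differs from compound 1 by a group of 10 heavy atoms (7 carbon, 1 nitrogen, 2 sulfur; one six-membered aromatic ring with 1 hetero atom) in place of a group of 12 heavy atoms (9 carbon, 1 nitrogen, 2 oxygen; one six-membered aromatic ring with 1 hetero atom), on a saturated chain carbon bound to an oxygen on a saturated carbon and two saturated chain carbons. For the measured compounds named here, the only measured step in one place is a 1.3-fold lower number from compound 1 to compound 2 (0.11 log units; within the scatter). That step is small, but it alters a single group on an oxygen and does not replace the whole group that changes here. Going by the values given here, no measured step exchanges that group, so the evidence is indirect and the range must stay wide. In this assay, a modest drop is expected at most, with no clear move beyond the scatter. The expected change is a 1.8-fold lower number from compound 1 to compound 4 (0.26 log units; within the scatter).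

For compound 4 the estimate is 6000 ng.h/mL, with an expected range of 1800 ng.h/mL to 15000 ng.h/mL.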

Compound 4, area under the concentration-time curve: 3900 ng.h/mL
Compound 4: the middle estimate sits 1.5-fold (0.19 log units) above what was measured; the range from low to high includes it.
By their numbers in this assay, from the lowest: compound 3; then compound 4; then compounds 2 and 1 (each within the scatter of the next).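

In this assay, the group of 10 heavy atoms with 2 sulfur, in place of the group of 12 heavy atoms with 2 oxygen, gives a 2.8-fold lower number from compound 1 to compound 4 (0.45 log units; beyond the scatter) and so lies beyond the scatter. The earlier step, a 1.3-fold lower number from compound 1 to compound 2 (0.11 log units; within the scatter), stayed within the scatter, so at this position a change on an oxygen alone left no readable shift, whereas exchanging the whole group did. No measurement at hand bears on the reason for this lower exposure.

As far as these compounds go, it remains open whether exchanging only one of the two oxygens for sulfur on this group, with the rest of compound 1 kept, would already give a step beyond the scatter. Also open, from the compounds shown here alone, is how exposure would respond to an amine or a longer alkyl chain on the same ring.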